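From Methoxymethyl to Hydroxymethyl: An Unmeasured Step

A few compounds are considered here, and "the series" means these few. Any claim that something is new, unique, unknown or untested is made for them only; others in the source may bear on it.

In a functional assay on A549 cells (Homo sapiens) for antiproliferative activity, read by MTT assay, with a stated time of 48 h (a lower number here means a stronger inhibitor, a higher number a weaker inhibitor), compound 1 `CNCC(=O)Nc1cc(OC)ccc1C(=O)c1ccc2c(c1)C=CC(C)(C)O2` gives 800 nM and compound 2 `C=C(c1cc(OC)c(OC)c(OC)c1)c1ccc(OC)cc1NC(=O)CNC` gives 100 nM. Compound 3 `C=C(c1cc(OC)c(OC)c(OC)c1)c1ccc(OC)c(O)c1NC(=O)COC` gives 190 nM, a number within the scatter of that of compound 2 and clearly lower than that of compound 1. Compound 4 `C=C(c1cc(OC)c(OC)c(OC)c1)c1ccc(OC)c(O)c1NC(=O)CO` differs from compound 3 by hydrogen in place of methyl on an oxygen on a saturated carbon, methoxymethyl to hydroxymethyl (hydrogen in place of methyl on an oxygen on a saturated carbon). For the measured compounds named here, no measured pair shows this change, so the expectation rests on compound 3 alone, at 190 nM. No step beyond the scatter is expected in this assay, and the estimated step of a 1.1-fold higher number from compound 3 to compound 4 (0.02 log units; within the scatter) is small. Compound 4 is expected at 200 nM, with an estimated range of 80 nM to 500 nM.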

Compound 4, half-maximal inhibitory concentration: 10 nM
Compound 4: the middle estimate sits 20-fold (1.30 log units) above what was measured; measured number outside the range, below it.
By their numbers in this assay, from the lowest: compound 4; then compounds 2 and 3 (each within the scatter of the next); then compound 1.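

In this assay the change from methoxymethyl to hydroxymethyl gives a 19-fold lower number from compound 3 to compound 4 (1.28 log units; beyond the scatter) and so shows that this position, on an oxygen on a saturated carbon, is highly sensitive to a single methyl. The earlier compounds shown here held no pair differing in one place, so they could not show this. No measurement shown here accounts for the size of the step.

Going by these compounds, how an amine, a carboxylic acid or a longer chain in place of hydroxymethyl would read in this assay stays open. So does whether the same change would give a step of this size on another core.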